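Swapping Phenoxy for Iodo in Compound 4

The source may hold more compounds than are shown below. What is called first, only, known or untested is meant among the compounds shown, and "the series" means these compounds.

Of the compounds shown here, three that share one core have been measured in a functional assay on cells (Splenocyte, Mus musculus, strain BALB/c) for inhibition, read by scintillation counting and thymidine incorporation, with a stated time of 72 h; on this read-out higher numbers stand for weaker inhibition and lower numbers for stronger inhibition. Compound 1 `CC(/C=N/Nc1ccc([N+](=O)[O-])cc1)=N\NC(=O)c1ccc(O)cc1` gives 1510 nM in this assay. Compound 2 `CC(/C=N/Nc1ccc([N+](=O)[O-])cc1)=N\NC(=O)c1ccccc1C` gives 6000 nM. Compound 3 `CC(/C=N/Nc1ccc([N+](=O)[O-])cc1)=N\NC(=O)c1ccccc1Oc1ccccc1` is reported only as a limit of the assay, > 12000 nM, so its true number is not known (the limit of > 12000 nM in this assay, at which 1 of the 3 values shown sits). The two measured steps both ran toward weaker inhibition: a 4.0-fold higher number from compound 1 to compound 2 (0.60 log units; beyond the scatter), and then an at least 2.0-fold higher number from compound 2 to compound 3 (0.30 log units; that floor lies within the scatter).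

Compound 4 `CC(/C=N/Nc1ccc([N+](=O)[O-])cc1)=N\NC(=O)c1ccccc1I` differs from compound 3 by iodo in place of phenoxy on an aromatic carbon. The step from compound 2 to compound 3 is the one that bears on this change, since it covered the arrival of the phenoxy group that now leaves, and the iodo group that enters brings one heavy atom where phenoxy brought seven. A return toward the level of compound 2 is therefore expected, that is a lower number and stronger inhibition, though not beyond the scatter with certainty because the starting point is only a limit (the limit of > 12000 nM in this assay, at which 1 of the 3 values shown sits). Compound 4 is expected to give 6000 nM in this assay, within a range from 2500 nM to 15000 nM. That estimate would mean an at least 2.0-fold lower number from compound 3 to compound 4 (0.30 log units; that floor lies within the scatter).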

Compound 4, half-maximal inhibitory concentration: 2980 nM
Compound 4: the middle estimate sits 2.0-fold (0.30 log units) above what was measured; measured number inside the range.
By their numbers in this assay, from the lowest: compounds 1, 4 and 2 (each within the scatter of the next, the first and the last beyond it). At a limit, above all of these: compound 3.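

In this assay the change from phenoxy to iodo on this aromatic carbon brings inhibition back (an at least 4.0-fold lower number from compound 3 to compound 4 (0.60 log units; beyond the scatter)), so the loss seen with phenoxy does not extend to every group other than methyl at this place. Iodo and methyl here cannot be told apart (a 2.0-fold lower number from compound 2 to compound 4 (0.30 log units; within the scatter)), and neither can 2-iodophenyl and 4-hydroxyphenyl (a 2.0-fold higher number from compound 1 to compound 4 (0.30 log units; within the scatter)), which places compound 4 within the scatter of two compounds that lie beyond the scatter of each other. From the compounds shown here alone, the reading for compound 3 remains a limit of the assay, so the full size of the first step stays unknown: the limit of > 12000 nM in this assay, at which 1 of the 4 values shown sits.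

Going by these compounds, how an amine or a carboxylic acid on this aromatic carbon would read in this assay remains open. Also open, on these data alone, is whether iodo would read the same at the place held by the hydroxy group of compound 1.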